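The source may report more compounds than this note shows. Statements on the series, on what has been measured and on what is new or still open speak of the compounds shown alone.

Measured so far:
compound 1 `Cc1cc(C(=O)NC(C)C)nn1Cc1cc(Cl)cc2cc(-c3ccccc3)oc12`: 10 nM
compound 2 `Cc1cc(C(=O)N[C@H]2CC[C@H](O)CC2)nn1Cc1cc(Cl)cc2cc(-c3ccccc3)oc12`: 7.94 nM

In an assay on CHO-K1 cells for displacement of a labelled ligand from prostaglandin E2 receptor EP1 subtype (Homo sapiens), read by scintillation counting, with a stated time of 45 min (on this read-out lower numbers stand for stronger inhibition and higher numbers for weaker inhibition), compound 2 stands level with compound 1: the step of a 1.3-fold lower number from compound 1 to compound 2 (0.10 log units; within the scatter) is within the scatter. Compound 3 `Cc1cc(C(=O)NCC(O)C(F)(F)F)nn1Cc1cc(Cl)cc2cc(-c3ccccc3)oc12` differs from compound 2 by 3,3,3-trifluoro-2-hydroxypropyl in place of 4-hydroxycyclohexyl on an amide-type nitrogen. Among the measured compounds shown here, only that one step bears on this position, and it was small, so the amide nitrogen substituent appears tolerant of change across these two compounds; no step beyond the scatter is expected here either. The estimate for compound 3 is 10 nM, with a range of 3 nM to 32 nM, which means an expected step of a 1.3-fold higher number from compound 2 to compound 3 (0.10 log units; within the scatter).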

Compound 3, half-maximal inhibitory concentration: 25.1 nM
Estimate against measurement, compound 3: 2.5-fold (0.40 log units) below; low and high end bracket the measured number.
By their numbers in this assay, from the lowest: compounds 2 and 1 (each within the scatter of the next); then compound 3.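

In this assay the amide nitrogen proves not fully tolerant: 3,3,3-trifluoro-2-hydroxypropyl gives a 3.2-fold higher number from compound 2 to compound 3 (0.50 log units; beyond the scatter) and also a 2.5-fold higher number from compound 1 to compound 3 (0.40 log units; beyond the scatter) as modest steps, whereas isopropyl and 4-hydroxycyclohexyl stand level. Among the compounds shown here, the first step beyond the scatter at this position thus comes with an open chain carrying fluorine, although the heavy-atom count matches that of 4-hydroxycyclohexyl. Nothing at hand explains this step.

The compounds shown do not separate the fluorine atoms from the absence of a ring, a question on which a plain 2-hydroxypropyl group would bear. On these data alone, how an amine or a carboxylic acid on this chain would read also remains open.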